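Para substituent on the benzoyl ring of the shared core

The compounds below may be only part of what the source reports. "The series", "measured", "known", "first", "only" and "open" are said of these compounds alone.

Among the measured compounds shown here, compound 2 `CCOC(=O)[C@@H]1/C(=C/C(=O)c2ccc(F)cc2)N=C(C)/C(=C(/O)OCC)[C@H]1c1ccccc1C(F)(F)F` holds the lower of the two numbers measured so far in an assay on brain for binding affinity to Voltage-gated L-type calcium channel (Rattus norvegicus) (on this read-out higher numbers stand for weaker inhibition and lower numbers for stronger inhibition), where compound 2 gives 117 nM. For the measured compounds named here, its nearest neighbour is compound 1 `CCOC(=O)[C@@H]1/C(=C/C(=O)c2ccccc2)N=C(C)/C(=C(/O)OCC)[C@H]1c1ccccc1C(F)(F)F`, and in this assay compound 1 gives 297 nM; the single measured step, a 2.5-fold lower number from compound 1 to compound 2 (0.40 log units; beyond the scatter), lies beyond the scatter. Compound 3 `CCOC(=O)[C@@H]1/C(=C/C(=O)c2ccc(N(C)C)cc2)N=C(C)/C(=C(/O)OCC)[C@H]1c1ccccc1C(F)(F)F` carries the change (dimethylamino in place of fluoro on an aromatic carbon). Going by the values given here, no measured step covers this replacement: the only step in hand swaps hydrogen for fluoro on the same aromatic carbon, and it was a modest move. Dimethylamino differs from fluoro in what is counted, so neither the direction nor the size of the next step can be read off from that one step; the data give no ground for a move beyond the scatter. For compound 3 the step expected in this assay is a 1.3-fold higher number from compound 2 to compound 3 (0.11 log units; within the scatter), small and uncertain in direction. For compound 3 the estimated value in this assay is 150 nM, with a range from 50 nM to 450 nM.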

Compound 3, half-maximal inhibitory concentration: 31.7 nM
The estimate for compound 3 lay 4.7-fold (0.68 log units) above the measured number; measured number below the stated range.
By their numbers in this assay, from the lowest: compound 3; then compound 2; then compound 1.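

At the aromatic carbon para to a large group, three substituents can now be compared in this assay. The number falls in the order hydrogen, fluoro, dimethylamino, with a 3.7-fold lower number from compound 2 to compound 3 (0.57 log units; beyond the scatter) for the latest replacement and a 9.4-fold lower number from compound 1 to compound 3 (0.97 log units; beyond the scatter) across the whole series. The earlier pair showed only that a single fluorine is accepted here, whereas compound 3 shows that the same carbon also takes a group of three heavy atoms, including a nitrogen and one hydrogen-bond acceptor, without any loss, and its steps to both other compounds lie beyond the scatter. No measurement shown here accounts for the gain.

On these data alone, it remains open whether the gain depends on the nitrogen or follows from the larger group, which a methoxy group or an unsubstituted amine on this carbon would help to separate. A longer chain on the nitrogen, such as diethylamino, would test whether the number keeps falling or whether dimethylamino already marks the limit of what this position accepts.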